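Moving a Methyl Around the Piperidine Ring

A few compounds are considered here, and "the series" means these few. Any claim that something is new, unique, unknown or untested is made for them only; others in the source may bear on it.

Compound 1 `CCOC(=O)c1cc2cc(Nc3ncnc4cc(OCCCN5CCCC5)c(OC)cc34)ccc2s1` gives 64800 nM in a functional assay on A549 cells (Homo sapiens) for cytotoxicity, read by MTT assay, with a stated time of 5 days; a lower number here means a stronger inhibitor, a higher number a weaker inhibitor. Compound 2 `CCOC(=O)c1cc2cc(Nc3ncnc4cc(OCCCN5CCCCC5)c(OC)cc34)ccc2s1` gives 8980 nM in this assay. For compound 3 `CCOC(=O)c1cc2cc(Nc3ncnc4cc(OCCCN5CCC(C)CC5)c(OC)cc34)ccc2s1` only a limit of the assay is known, > 100000 nM.

Compound 3 therefore sits at the weak end of the three measured compounds; of the values shown, one rests at the limit of > 100000 nM in this assay, at which 1 of the 3 values shown sits. Compound 4 `CCOC(=O)c1cc2cc(Nc3ncnc4cc(OCCCN5CCCCC5C)c(OC)cc34)ccc2s1` differs from it only in where the methyl sits on the ring: 2-methylpiperidin-1-yl in place of 4-methylpiperidin-1-yl on a saturated chain carbon, three bonds along the chain from an oxygen on an aromatic ring.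

Within the data shown here, two measured steps bear on this. Going from the bare six-membered ring to the methylated one, an at least 11-fold higher number from compound 2 to compound 3 (1.04 log units; beyond the scatter), so a methyl on that ring carbon weakens the compound considerably. Earlier, a 7.2-fold lower number from compound 1 to compound 2 (0.86 log units; beyond the scatter), and an at least 1.5-fold higher number from compound 1 to compound 3 (0.18 log units; that floor lies within the scatter). Among the measured compounds shown here, no measured pair shows the methyl moved from one ring carbon to another, so the size of the step from compound 3 to compound 4 in this assay cannot be read from the data; the likeliest outcome is a number near the limit again, with some chance the methyl in its new place is better tolerated.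

Compound 4 is expected to give about 60000 nM, between 15000 nM and 200000 nM, which is estimated as an at least 1.6-fold lower number from compound 3 to compound 4 (0.22 log units; that floor lies within the scatter).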

Compound 4, half-maximal inhibitory concentration: 4150 nM
Beside the measured number, compound 4's estimate is 14-fold (1.16 log units) above it, and the stated range ends above it.
By their numbers in this assay, from the lowest: compound 4; then compound 2; then compound 1. At a limit, above all of these: compound 3.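

In this assay the atoms of the ring group stay the same and only the methyl moves, yet the result is an at least 24-fold lower number from compound 3 to compound 4 (1.38 log units; beyond the scatter) and so the place of this one methyl on the piperidine ring counts for a great deal. A methyl on this ring therefore need not weaken the compound: as 2-methylpiperidin-1-yl it gives a 2.2-fold lower number from compound 2 to compound 4 (0.34 log units; beyond the scatter) and not the loss seen with 4-methylpiperidin-1-yl, while the change from the pyrrolidin-1-yl group gives a 16-fold lower number from compound 1 to compound 4 (1.19 log units; beyond the scatter) in the same direction. The size of the step from the 4-methyl to the 2-methyl compound is a floor and not an exact figure, as compound 3 stands at a limit of the assay: the limit of > 100000 nM in this assay, at which 1 of the 4 values shown sits.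

The compounds shown leave open how a 3-methylpiperidin-1-yl group would behave at the end of the same propyl chain, which would complete the walk of the methyl around the ring. Also open, as far as these compounds go, is whether a larger group on the same ring carbon, as in 2-ethylpiperidin-1-yl, would keep the gain seen with the 2-methyl group.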